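Chloro to Fluoro on the Shared Core: Cytotoxicity Expected

This account rests on a few compounds, and the source may have more. Where it says the series, first, only, none or still open, it means among the compounds named here.

compound 1, `O=C(O)/C(O)=C/C(=O)c1cn(Cc2ccc(C(F)(F)F)cc2)c2ccc(Cl)cc12`, 23000 nM in an ADME assay on MT4 cells (Homo sapiens) for cytotoxicity, read by MTT assay; on this read-out higher numbers stand for lower toxicity in this test and lower numbers for higher toxicity in this test
compound 2, `Cc1cc(C)cc(Cn2cc(C(=O)/C=C(\O)C(=O)O)c3cc(Cl)ccc32)c1`, > 125000 nM in this assay

Of the compounds shown here, two have been measured in this assay. Going by the values given here, compound 1 gives the only number, 23000 nM. For compound 2 the value of > 125000 nM is a limit of the assay, not a number; this is the limit of > 125000 nM in this assay, at which 1 of the 2 values shown sits. Among the compounds with values here, no step between measured compounds that differ in one place is available, so the two values are simply what they show, with compound 1 giving a number and compound 2 giving only a limit.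

Compound 3, `O=C(O)/C(O)=C/C(=O)c1cn(Cc2ccc(C(F)(F)F)cc2)c2ccc(F)cc12`, is not yet measured. It differs from compound 1 in one place: fluoro in place of chloro on an aromatic carbon. Within the data shown here, with no measured step of this kind to lean on, the step from compound 1 to compound 3 is expected to be small, in either direction, and quite possibly none beyond the scatter. Compound 3 is therefore estimated at 35000 nM in this assay, within a range of 12000 nM to 110000 nM, which means an expected step of a 1.5-fold higher number from compound 1 to compound 3 (0.18 log units; within the scatter).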

Compound 3, half-maximal cytotoxic concentration: 15000 nM
For compound 3 the middle estimate is 2.3-fold (0.37 log units) above the measured one, within the range that was stated.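

The one-place change now available, fluoro in place of chloro on this aromatic carbon, leaves the read-out of this assay within the scatter (a 1.5-fold lower number from compound 1 to compound 3 (0.19 log units; within the scatter)). At this position, meta to a fused ring and para to a fused ring, the two halogens therefore cannot be told apart in this test, and compound 3, like compound 1, gives a number rather than a limit. No measurement shown here speaks to the origin of this step.

Open, going by these compounds, is whether a methoxy, a nitrile or an amine on this same carbon would move the read-out beyond the scatter. Also open, on these data alone, is whether the same exchange would give a like step on compound 2, which stands only at a limit of the assay.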